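A few compounds are considered here, and "the series" means these few. Any claim that something is new, unique, unknown or untested is made for them only; others in the source may bear on it.

Measured so far:
- compound 1, `CC1(Nc2ccc(NC(=O)c3cc(Cl)ccc3O)c(Cl)c2)CCCC1`: 157000 nM
- compound 2, `O=C(Nc1ccc(NCc2cccc(C(F)(F)F)c2)cc1Cl)c1cc(Cl)ccc1O`: 13300 nM

Both values come from an ADME assay on A549 cells (Homo sapiens) for cytotoxicity, read by resazurin assay, with a stated time of 48 h; a higher number here means that more compound is tolerated, a lower number that less compound is tolerated. Of the two numbers, compound 2 stands lowest; compound 1 gives the higher number, and the gap between the two lies beyond the usual scatter of repeated measurements, so compound 2 is the less tolerated of the pair. Going by the values given here, no single-change step between measured compounds is available, so nothing is known yet about how a change at the saturated chain carbon bound to a nitrogen on an aromatic ring moves the number.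

Compound 3, `O=C(Nc1ccc(NCc2cccc(Br)n2)cc1Cl)c1cc(Cl)ccc1O`, is the next compound for this assay. It differs from compound 2 in one place: 6-bromopyridin-2-yl in place of 3-(trifluoromethyl)phenyl on a saturated chain carbon bound to a nitrogen on an aromatic ring. Among the compounds with values here, with no measured step of this kind to lean on, the expectation for a 1.5-fold higher number from compound 2 to compound 3 (0.18 log units; within the scatter) is a small step, if any, within or near the scatter, with a slight lean toward a higher number. Compound 3 is accordingly estimated at 20000 nM, with a likely range from 7000 nM to 60000 nM.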

Compound 3, half-maximal cytotoxic concentration: 92300 nM
For compound 3 the middle estimate is 4.6-fold (0.66 log units) below the measured one, outside the stated range (above it).
By their numbers in this assay, from the lowest: compound 2; then compounds 3 and 1 (each within the scatter of the next).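

In this assay, going by these compounds alone, the swap at the saturated chain carbon bound to a nitrogen on an aromatic ring is the first measured change at this place, and 6-bromopyridin-2-yl in place of 3-(trifluoromethyl)phenyl gives a 6.9-fold higher number from compound 2 to compound 3 (0.84 log units; beyond the scatter). The group on this carbon therefore matters to the number, while (6-bromopyridin-2-yl)methyl in place of 1-methylcyclopentyl on a nitrogen on an aromatic ring gives a 1.7-fold lower number from compound 1 to compound 3 (0.23 log units; within the scatter), which leaves these two groups unseparated. Nothing measured bears on the cause of the larger step.

The step from 3-(trifluoromethyl)phenyl to 6-bromopyridin-2-yl alters the ring atoms and the substituent together, and the compounds shown do not separate the two changes. Where 3-bromophenyl or plain pyridin-2-yl would stand at this place remains open.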